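A few compounds are considered here, and "the series" means these few. Any claim that something is new, unique, unknown or untested is made for them only; others in the source may bear on it.

Compound 1 `CO[C@@H]1COCC[C@@H]1N[C@@H]1CC[C@@](C(=O)N2C[C@@H]3C[C@H]2CN3C(=O)CC(C)(C)C)(C(C)C)C1`: > 2 h (a limit)
Compound 2 `CO[C@@H]1COCC[C@@H]1N[C@@H]1CC[C@@](C(=O)N2C[C@@H]3C[C@H]2CN3C(=O)C(C)(C)C)(C(C)C)C1`: > 2 h (a limit)

In an in vitro ADME assay on microsomes from liver (Homo sapiens) for metabolic stability, tested at 1 uM (on this read-out lower numbers stand for a shorter-lived compound and higher numbers for a longer-lived compound), compound 2 gives > 2 h, which is a limit of the assay and not a number. Its place on the scale is therefore known only as the limit of > 2 h in this assay, at which 2 of the 2 values shown sit.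

Compound 3 `CO[C@@H]1COCC[C@@H]1N[C@@H]1CC[C@@](C(=O)N2C[C@@H]3C[C@H]2CN3C(=O)C2CCC2)(C(C)C)C1` differs from compound 2 in a single group on a carbonyl carbon: cyclobutyl in place of tert-butyl on a carbonyl carbon. In words, cyclobutyl stands in place of tert-butyl.

Going by the values given here, only one measured step bears on this site: a step that the two limits leave unreadable from compound 1 to compound 2. That step has no readable size and gives no direction to carry over. For the change to compound 3, no shift beyond the usual scatter is therefore expected, and the expected step is a step that the limit leaves unreadable from compound 2 to compound 3.

Compound 3 is estimated at 2.5 h, with an expected range from 1 h to 6 h.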

Compound 3, half-life: > 2 h
Compound 3 ended at the assay's limit; the forecaster's own chance of this, stated with the estimate: 60%; the middle value is on the limit's open side.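

The steps among compound 1, compound 2 and compound 3 cannot be read, because all three give a limit of the assay and not a number: the limit of > 2 h in this assay, at which 3 of the 3 values shown sit.

Going by these compounds, how long each half-life really runs, and whether neopentyl, tert-butyl or cyclobutyl on the carbonyl carbon changes it, stays open.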